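Cyclopropyl for Methyl on the Amide Nitrogen

The source may report more compounds than this note shows. Statements on the series, on what has been measured and on what is new or still open speak of the compounds shown alone.

Compound 1, `N#Cc1cccc(S(=O)(=O)Oc2ccc(-c3cncn3C3CCN(C(=O)c4ccc(Cl)c(C(F)(F)F)c4)CC3)cc2)c1`: 4.28 nM
Compound 2, `CNC(=O)c1cccc(S(=O)(=O)Oc2ccc(-c3cncn3C3CCN(C(=O)c4ccc(Cl)c(C(F)(F)F)c4)CC3)cc2)c1`: 1.76 nM

In an assay on THP-1 cells for antagonist activity at P2X purinoceptor 7 (Homo sapiens), read by ELISA, with a stated time of 30 min (on this read-out higher numbers stand for weaker inhibition and lower numbers for stronger inhibition), compound 2 gives the lower of the two numbers. Within the data shown here, the only step measured so far, a 2.4-fold lower number from compound 1 to compound 2 (0.39 log units; beyond the scatter), replaced cyano on an aromatic carbon with methylcarbamoyl. Compound 3, `O=C(NC1CC1)c1cccc(S(=O)(=O)Oc2ccc(-c3cncn3C3CCN(C(=O)c4ccc(Cl)c(C(F)(F)F)c4)CC3)cc2)c1`, keeps that carbamoyl group and differs from compound 2 only by cyclopropyl in place of methyl on an amide-type nitrogen. Among the measured compounds shown here, no measured step touches the substituent on the amide nitrogen, so the one step does not bear directly on this change; it only shows that the carbamoyl end tolerates variation while the number stays low. With nothing pointing in either direction, the expectation for compound 3 is a step of a 1.1-fold higher number from compound 2 to compound 3 (0.06 log units; within the scatter) that stays within the scatter. Compound 3 is therefore estimated at 2 nM in this assay, with a range from 0.8 nM to 5 nM.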

Compound 3, half-maximal inhibitory concentration: 58 nM
Compound 3: the middle estimate sits 29-fold (1.46 log units) below what was measured; the whole stated range lies below it.
By their numbers in this assay, from the lowest: compound 2; then compound 1; then compound 3.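

In this assay the substituent on the amide nitrogen proves to be far from neutral: cyclopropyl in place of methyl gives a 33-fold higher number from compound 2 to compound 3 (1.52 log units; beyond the scatter) and so removes the low number that methylcarbamoyl had reached. The carbamoyl end therefore does not accept every variation, since cyclopropylcarbamoyl in place of cyano gives a 14-fold higher number from compound 1 to compound 3 (1.13 log units; beyond the scatter) and leaves compound 3 behind the nitrile compound 1, the opposite of what methylcarbamoyl did. Nothing available here accounts for this loss.

The compounds shown leave open whether the rise belongs to the three-membered ring itself or would come with any group other than methyl on that nitrogen. An ethyl or isopropyl group there, or the bare amide hydrogen in place of methyl, would separate these readings.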